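A few compounds are considered here, and "the series" means these few. Any claim that something is new, unique, unknown or untested is made for them only; others in the source may bear on it.

Compound 3 `CCCn1c(=O)n(C)c(=O)c2c1ncn2CCC(=O)O` stands at the edge of what this work can resolve: in an assay on Cerebral cortex for binding affinity to adenosine receptor A1 (Cavia porcellus), read by radioligand binding (a higher number here means a weaker inhibitor, a lower number a stronger inhibitor), compound 3 gives > 200000 nM, which is a limit of the assay rather than a number. The change to compound 4 `CCCn1c(=O)n(C)c(=O)c2c1ncn2CC(C)=O` is acetyl in place of carboxymethyl on a saturated chain carbon bound to an aromatic nitrogen. Among the measured compounds shown here, one measured step bears on it. Compound 1 `CCCn1c(=O)n(CC(=O)O)c(=O)c2[nH]cnc21` gives > 200000 nM in this assay, again a limit. Compound 2 `CCCn1c(=O)n(CCCCC(C)=O)c(=O)c2[nH]cnc21` gives 23100 nM in this assay, a measurable number. The step of an at least 8.6-fold lower number from compound 1 to compound 2 (0.93 log units; beyond the scatter) shows the exchange of an acid for a ketone moving a compound off the limit; the limit of > 200000 nM in this assay, at which 2 of the 3 values shown sit, marks where both limits sit. By the same kind of exchange, compound 4 is expected to reach a measurable number, with an estimated at least 5.0-fold lower number from compound 3 to compound 4 (0.69 log units; beyond the scatter), so that compound 4 is expected at 40000 nM, somewhere between 8000 nM and 200000 nM.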

Compound 4, inhibition constant: 95700 nM
The estimate for compound 4 lay 2.4-fold (0.38 log units) below the measured number; low and high end bracket the measured number.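

The step, an at least 2.0-fold lower number from compound 3 to compound 4 (0.32 log units; beyond the scatter), shows that the exchange of an acid for a ketone also lifts a compound off the limit when it is made on this saturated chain carbon bound to an aromatic nitrogen, on a second substitution pattern of the shared core. Across the compounds shown, both carboxylic acids give only a limit, while both ketones give numbers: the limit of > 200000 nM in this assay, at which 2 of the 4 values shown sit.

From the compounds shown here alone, the true size of the step stays unknown, as compound 3 has only a limit. Going by these compounds, whether an amide, an amine or a longer ketone chain at this place would give a lower number remains open.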